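From Compound 2 to Compound 4: One Methyl Further

A few compounds are considered here, and "the series" means these few. Any claim that something is new, unique, unknown or untested is made for them only; others in the source may bear on it.

Three compounds have been measured in an assay on cell membranes for inhibition of cytochrome P450 1A1 (Homo sapiens), read by fluorescence, using microsomes, with a stated time of 10 min; a lower number here means a stronger inhibitor, a higher number a weaker inhibitor:

Compound 1, `COc1ccc(/C=C/C(=O)c2ccncc2)cc1`, gives 6310 nM.
Compound 2, `CCOc1c(OC)cc(/C=C/C(=O)c2ccncc2)cc1OC`, gives 230 nM.
Compound 3, `COc1cccc(/C=C/C(=O)c2ccncc2)c1`, gives 590 nM.

Compound 2 stands at the lowest of the three numbers. Its nearest neighbour is compound 3, and that gap lies beyond the usual scatter; compound 1 stands much further off. For the measured compounds named here, no two of the measured compounds differ in only one place, so no single structural step has a known size from these data; the numbers of compound 2 and compound 3 simply show that the two sit apart.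

The next compound, compound 4, `CCOc1cc(/C=C/C(=O)c2ccncc2)cc(OC)c1OCC`, is not yet measured. Set against compound 2 it shows (methyl in place of hydrogen on a saturated chain carbon bound to an oxygen on an aromatic ring). The same difference, cut one bond further out, reads methyl to ethyl; methoxy to ethoxy. Nothing in the measured set isolates this change, so its effect in this assay can only be guessed: the step is expected to be small, with no clear direction, and probably not beyond the scatter.

For compound 4 the expected value in this assay is 260 nM, with a range from 90 nM to 750 nM. The estimated step of a 1.1-fold higher number from compound 2 to compound 4 (0.05 log units; within the scatter) is expected to stay within the scatter.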

Compound 4, half-maximal inhibitory concentration: 65 nM
Estimate against measurement, compound 4: 4.0-fold (0.60 log units) above; measured number outside the range, below it.
By their numbers in this assay, from the lowest: compound 4; then compound 2; then compound 3; then compound 1.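

In this assay, the change from methoxy to ethoxy, a methyl in place of hydrogen on a saturated chain carbon bound to an oxygen on an aromatic ring, gives a 3.5-fold lower number from compound 2 to compound 4 (0.55 log units; beyond the scatter). For the compounds shown here, this is the first step in the set with a known size, since no two of the earlier compounds differed in only one place, and it shows that this position responds to a single methyl: the number moves toward stronger inhibition, by a modest amount but beyond the scatter. The data offer no measurement that accounts for the step, so the reason for it remains unexplained.

The compounds shown leave open whether a longer chain such as propyl, or a branched group such as isopropyl, on the same oxygen would lower the number further or reverse the step, and how an amine or a hydroxyl group would fare there. They also leave open whether the same change from methoxy to ethoxy would produce a step of similar size and direction on compound 1 or compound 3, whose substitution differs from that of compound 2.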